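Moving the chlorine in a bombesin receptor subtype-3 agonist

The compounds below may be only part of what the source reports. "The series", "measured", "known", "first", "only" and "open" are said of these compounds alone.

Compound 2 `O=C(O)c1ccccc1-c1ccc(CCc2ncc(Cc3ccccc3Cl)[nH]2)cc1` gives 292 nM in an in vitro functional assay on cells for agonist activity at Bombesin receptor subtype-3 (Homo sapiens), read by luminescence and calcium flux (a higher number here means that more compound is needed for the effect, a lower number that less compound is needed), the lowest of the three numbers at hand. Compound 1 `COc1ccc(Cc2cnc(CCc3ccc(-c4ccccc4C(=O)O)cc3)[nH]2)cc1` gives 5360 nM, and compound 3 `Cc1ccc(Cc2cnc(CCc3ccc(-c4ccccc4C(=O)O)cc3)[nH]2)cc1` gives 2660 nM. Compound 4 `O=C(O)c1ccccc1-c1ccc(CCc2ncc(Cc3cccc(Cl)c3)[nH]2)cc1` is not yet measured; it differs from compound 2 in one place: 3-chlorophenyl in place of 2-chlorophenyl on a saturated chain carbon bound to an aromatic carbon. Among the measured compounds shown here, two measured steps bear on this change: an 18-fold lower number from compound 1 to compound 2 (1.26 log units; beyond the scatter) and a 9.1-fold higher number from compound 2 to compound 3 (0.96 log units; beyond the scatter), while a 2.0-fold lower number from compound 1 to compound 3 (0.30 log units; within the scatter). For the measured compounds named here, no measured compound carries 3-chlorophenyl at this place, so the direction of the move is uncertain. A modest rise is expected, a 2.4-fold higher number from compound 2 to compound 4 (0.38 log units; beyond the scatter), because a 9.1-fold higher number from compound 2 to compound 3 (0.96 log units; beyond the scatter) and an 18-fold lower number from compound 1 to compound 2 (1.26 log units; beyond the scatter) both show the other groups tried at this place giving higher numbers. Compound 4 is therefore estimated at 700 nM, between 250 nM and 2500 nM.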

Compound 4, half-maximal effective concentration: 825 nM
Estimate against measurement, compound 4: 1.2-fold (0.07 log units) below; the measured number falls inside the stated range.
By their numbers in this assay, from the lowest: compound 2; then compound 4; then compounds 3 and 1 (each within the scatter of the next).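

Moving the chlorine from 2-chlorophenyl to 3-chlorophenyl, with the same atoms joined differently, gives a 2.8-fold higher number from compound 2 to compound 4 (0.45 log units; beyond the scatter) in this assay. The 3-chlorophenyl group still stands lower than the two groups without chlorine, with a 3.2-fold lower number from compound 3 to compound 4 (0.51 log units; beyond the scatter) and a 6.5-fold lower number from compound 1 to compound 4 (0.81 log units; beyond the scatter), so both chlorophenyl compounds give lower numbers than 4-methylphenyl and 4-methoxyphenyl. Nothing at hand explains why the place of the chlorine matters. The compounds shown leave open what 4-chlorophenyl would give here. They also leave open whether bromine or trifluoromethyl in place of that chlorine would keep the low number.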